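Lengthening an alkoxy group: from methoxy to heptyloxy

The compounds below may be only part of what the source reports. "The series", "measured", "known", "first", "only" and "open" are said of these compounds alone.

Compound 1 `O=C(Nc1cccnc1)c1ccccc1OCc1cc(Cl)ccc1Cl` gives 990 nM in an assay on lysate for inhibition of phosphatidylcholine:ceramide cholinephosphotransferase 2 (Homo sapiens), read by HPLC, with stated times of 30 min and 2 h; on this read-out higher numbers stand for weaker inhibition and lower numbers for stronger inhibition.
Compound 2 `COc1ccc(Cl)cc1COc1ccccc1C(=O)Nc1cccnc1` gives 670 nM in this assay.

Compound 2 and compound 1 cannot be separated here: the step of a 1.5-fold lower number from compound 1 to compound 2 (0.17 log units; within the scatter) falls within the scatter. Compound 3 `CCCCCCCOc1ccc(Cl)cc1COc1ccccc1C(=O)Nc1cccnc1` differs from compound 2 by hexyl in place of hydrogen on a saturated chain carbon bound to an oxygen on an aromatic ring. Going by the values given here, no measured step changes a chain in this way; the only step seen, chloro to methoxy, was within the scatter and says little about growing methoxy into heptyloxy. In this assay no step beyond the scatter is therefore expected, with wide uncertainty. Compound 3 is estimated at 600 nM, between 120 nM and 3000 nM, a step of a 1.1-fold lower number from compound 2 to compound 3 (0.05 log units; within the scatter).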

Compound 3, half-maximal inhibitory concentration: 430 nM
Compound 3: the middle estimate sits 1.4-fold (0.14 log units) above what was measured, and the stated range covers the measured number.
By their numbers in this assay, from the lowest: compounds 3, 2 and 1 (each within the scatter of the next, the first and the last beyond it).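

Growing methoxy into heptyloxy is tolerated in this assay: adding hexyl at this saturated chain carbon gives a 1.6-fold lower number from compound 2 to compound 3 (0.19 log units; within the scatter), so even this much added chain brings no change that can be told apart from the scatter. Set against the chloro of compound 1, heptyloxy gives a 2.3-fold lower number from compound 1 to compound 3 (0.36 log units; beyond the scatter), a modest step beyond the scatter. Nothing measured here offers an explanation for these numbers.

As far as these compounds go, whether butoxy or a longer chain than heptyloxy would read differently remains open. So does the effect of a chain carrying an amine or a carboxylic acid.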